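Chloro for Bromo: A Single Halogen Exchange

The source may report more compounds than this note shows. Statements on the series, on what has been measured and on what is new or still open speak of the compounds shown alone.

Measured compounds:
Compound 1, `O=C1N=C(N2CCC[C@H]2C(=O)Nc2ccc3ncnc(Nc4cccc(Cl)c4)c3c2)S/C1=C/c1ccc(Br)s1`, > 50000 nM
Compound 2, `O=C1N=C(N2CCC[C@H]2C(=O)Nc2ccc3ncnc(Nc4cccc(Cl)c4)c3c2)S/C1=C/c1ccccc1[N+](=O)[O-]`, 32500 nM
Compound 3, `O=C1N=C(N2CCC[C@H]2C(=O)Nc2ccc3ncnc(Nc4cccc(Cl)c4)c3c2)S/C1=C/c1cccc(Br)c1`, 21300 nM

In a functional assay on HepG2 cells (Homo sapiens) for antiproliferative activity, read by MTT assay (on this read-out lower numbers stand for stronger inhibition and higher numbers for weaker inhibition), compound 1 reaches only the assay limit, (the limit of > 50000 nM in this assay, at which 1 of the 3 values shown sits), and gives no number. Compound 2 and compound 3 give numbers; compound 3 stands lowest of the two, but the step of a 1.5-fold lower number from compound 2 to compound 3 (0.18 log units; within the scatter) lies within the scatter, so the two cannot be ordered. Against compound 1 the step of an at least 2.3-fold lower number from compound 1 to compound 3 (0.37 log units; beyond the scatter) is at least modest, while an at least 1.5-fold lower number from compound 1 to compound 2 (0.18 log units; that floor lies within the scatter) is only a floor within the scatter.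

Compound 4, `O=C1N=C(N2CCC[C@H]2C(=O)Nc2ccc3ncnc(Nc4cccc(Cl)c4)c3c2)S/C1=C/c1cccc(Cl)c1`, is not yet measured. It differs from compound 3 by chloro in place of bromo on an aromatic carbon. Among the measured compounds shown here, none of the measured steps exchanges one halogen for another on the same ring; all three replace the whole aryl group. The two phenyl compounds, compound 2 and compound 3, sit within the scatter of each other, and a change as small as chloro for bromo gives no ground to expect more.

Compound 4 is therefore estimated at 25000 nM in this assay, within 10000 nM to 60000 nM, a step of a 1.2-fold higher number from compound 3 to compound 4 (0.07 log units; within the scatter) expected to stay within the scatter.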

Compound 4, half-maximal inhibitory concentration: 27600 nM
The estimate for compound 4 lay 1.1-fold (0.04 log units) below the measured number; low and high end bracket the measured number.
By their numbers in this assay, from the lowest: compounds 3, 4 and 2 (each within the scatter of the next). At a limit, above all of these: compound 1.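

In this assay, exchanging one halogen for another on the same ring gives a 1.3-fold higher number from compound 3 to compound 4 (0.11 log units; within the scatter), so at this place on the aromatic ring chloro and bromo cannot be told apart. The step of a 1.2-fold lower number from compound 2 to compound 4 (0.07 log units; within the scatter) likewise leaves 3-chlorophenyl and 2-nitrophenyl unordered, and compounds 2, 3 and 4 now form a set whose members all lie within the scatter of each other. The step of an at least 1.8-fold lower number from compound 1 to compound 4 (0.25 log units; that floor lies within the scatter) is only a floor, set by a limit and not a number: the limit of > 50000 nM in this assay, at which 1 of the 4 values shown sits.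

As far as these compounds go, whether an amine or a carboxylic acid in place of the halogen would move the number beyond the scatter of compounds 2, 3 and 4 stays open. From the compounds shown here alone, it also stays open whether plain phenyl, without any halogen, would give a number in the same range.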